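Swapping benzyl for cyclopentyl when every value is a limit

A few compounds are considered here, and "the series" means these few. Any claim that something is new, unique, unknown or untested is made for them only; others in the source may bear on it.

Compound 1 `COCCOc1nc(N)nc2c1ncn2/C=C1/CC1(CO)CO`: > 20000 nM
Compound 2 `Nc1nc(OCc2ccccc2)c2ncn(/C=C3/CC3(CO)CO)c2n1`: > 20000 nM
Compound 3 `Nc1nc(NCc2ccccc2)c2ncn(/C=C3/CC3(CO)CO)c2n1`: > 20000 nM

In an ADME assay on CCRF-HSB-2 cells (Homo sapiens) for cytotoxicity, with a stated time of 7 days (a lower number here means that less compound is tolerated, a higher number that more compound is tolerated), compound 3 gives > 20000 nM, which is a limit of the assay and not a number. It has company, for the data show (the limit of > 20000 nM in this assay, at which 3 of the 3 values shown sit). So compound 3 cannot be ranked against the other two compounds.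

The next compound, compound 4 `Nc1nc(NC2CCCC2)c2ncn(/C=C3/CC3(CO)CO)c2n1`, keeps the shared core and changes one group, with cyclopentyl in place of benzyl on a nitrogen on an aromatic ring.

The closest measured change is a step that the two limits leave unreadable from compound 2 to compound 3, which also alters the group on the shared core at that spot. Two more changes bear on it less directly: a step that the two limits leave unreadable from compound 1 to compound 3 and a step that the two limits leave unreadable from compound 1 to compound 2. None of the three has a size that can be read, yet all three compounds stayed at the limit, and none goes against that pattern. No step beyond the scatter is therefore expected in this assay, and no direction can be named. The expected change is a step that the limit leaves unreadable from compound 3 to compound 4. Compound 4 is estimated at 30000 nM, with an expected range of 10000 nM to 80000 nM, and it may well be reported only as a limit.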

Compound 4, half-maximal cytotoxic concentration: > 20000 nM
Compound 4: no number, only a limit (the forecaster's own chance of this, stated with the estimate: 85%); the middle value does not contradict the limit.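

In this assay compound 4 gives > 20000 nM, which is a limit of the assay and not a number. For the compounds shown here, no step from compound 1, compound 2 or compound 3 to compound 4 can be read: the limit of > 20000 nM in this assay, at which 4 of the 4 values shown sit. The compounds shown leave open how much of each is actually tolerated, and whether benzylamino, cyclopentylamino, benzyloxy and 2-methoxyethoxy differ at all in this assay.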